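Methoxy at the meta position: from compound 2 to compound 3

A few compounds are considered here, and "the series" means these few. Any claim that something is new, unique, unknown or untested is made for them only; others in the source may bear on it.

Measured compounds in a functional assay on HeLa cells (Homo sapiens) for antiproliferative activity, read by MTT assay, with a stated time of 48 h; a lower number here means a stronger inhibitor, a higher number a weaker inhibitor:
- compound 1, `S=c1oc(-c2ccc3c(c2)OCCO3)nn1CN1CCN(c2cccc(Cl)c2)CC1`: 47200 nM
- compound 2, `S=c1oc(-c2ccc3c(c2)OCCO3)nn1CN1CCN(c2ccccc2)CC1`: > 50000 nM, a limit of the assay, not a number

The two measured compounds share a core and differ only at the aryl piperazine. In this assay compound 1 gives 47200 nM. For compound 2 the same assay returns only > 50000 nM, which is a limit rather than a measured value. For the measured compounds named here, the one step that can be read, an at least 1.0-fold higher number from compound 1 to compound 2 (0.02 log units; that floor lies within the scatter), is therefore only a floor, and it lies within the scatter; compound 2 stands at the limit described by the limit of > 50000 nM in this assay, at which 1 of the 2 values shown sits.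

Compound 3, `COc1cccc(N2CCN(Cn3nc(-c4ccc5c(c4)OCCO5)oc3=S)CC2)c1`, is not yet measured. It differs from compound 2 by methoxy in place of hydrogen on an aromatic carbon. Going by the values given here, the only measured step at this aromatic ring, an at least 1.0-fold higher number from compound 1 to compound 2 (0.02 log units; that floor lies within the scatter), shows that exchanging the substituent there moved the number little, if at all. On that basis the step from compound 2 to compound 3 is expected to be small, an at least 1.1-fold lower number from compound 2 to compound 3 (0.04 log units; that floor lies within the scatter), with no direction beyond the scatter. Compound 3 is thus estimated at 45000 nM, between 20000 nM and 100000 nM, with a real chance that only a limit is reported again.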

Compound 3, half-maximal inhibitory concentration: 18000 nM
Compound 3: the middle estimate sits 2.5-fold (0.40 log units) above what was measured, outside the stated range (below it).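

In this assay, for the compounds shown here, this aromatic ring now proves able to move the number: the only earlier step there was a floor within the scatter, whereas the change from phenyl to 3-methoxyphenyl gives an at least 2.7-fold lower number from compound 2 to compound 3 (0.44 log units; beyond the scatter). Methoxy also separates from chloro on this aromatic carbon, with a 2.6-fold lower number from compound 1 to compound 3 (0.42 log units; beyond the scatter), so the gain does not depend on the step that starts from a limit. That first step is itself only a floor, and its true size stays unknown, as compound 2 has a limit and not a number: the limit of > 50000 nM in this assay, at which 1 of the 3 values shown sits.

The compounds shown leave open whether an ethoxy group, a hydroxyl or an amine on this ring would carry the number further down, and whether methoxy elsewhere on the ring would do the same. They also leave open whether the difference between methoxy and chloro would persist with other changes to the shared core, and they offer no measured property that could explain that difference.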